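This account rests on a few compounds, and the source may have more. Where it says the series, first, only, none or still open, it means among the compounds named here.

Compound 1 `O=c1[nH]c(=O)n(COCCO)cc1[N+](=O)[O-]` opens the series. In a functional assay on Vero cells (Chlorocebus sabaeus) for cytotoxicity, read by MTT assay (on this read-out lower numbers stand for higher toxicity in this test and higher numbers for lower toxicity in this test), compound 1 gives only a limit, > 432000 nM. Compound 2 `O=c1[nH]c(=O)n(COCCO)cc1C(F)(F)F` carries trifluoromethyl in place of nitro on an aromatic carbon. In this assay compound 2 likewise gives only a limit, > 393000 nM. The step that the two limits leave unreadable from compound 1 to compound 2 therefore cannot be sized; both values stop at the assay ceiling, compound 2 at the limit of > 393000 nM in this assay, at which 1 of the 2 values shown sits, and compound 1 at the limit of > 432000 nM in this assay, at which 1 of the 2 values shown sits. Compound 2 thus stands among values that show no measurable cytotoxicity within the tested range.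

Compound 3 `O=c1[nH]c(=O)n(COCCO)cc1CO` differs from compound 2 by hydroxymethyl in place of trifluoromethyl on an aromatic carbon. For the measured compounds named here, no measured step bears on this change; the one step recorded in this assay is unreadable. With both neighbours at the ceiling, no shift beyond the scatter is expected, and compound 3 is estimated at 420000 nM (range 150000 nM to 1200000 nM), the expected step being a step that the limit leaves unreadable from compound 2 to compound 3, most likely reported again as a limit.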

Compound 3, half-maximal cytotoxic concentration: > 476000 nM
Compound 3 gave a limit, no number; the forecaster's own chance of this, stated with the estimate: 85%; at least 1.1-fold (0.05 log units) between middle value and limit.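

In this assay compound 3 gives only a limit, > 476000 nM. For the compounds shown here, with compound 1 and compound 2 also at limits, no step among the three can be read. The compounds shown leave open whether any group at this place on the shared core produces measurable cytotoxicity.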